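Swapping the naphthyl for a fluorophenyl on a shared core

The compounds below may be only part of what the source reports. "The series", "measured", "known", "first", "only" and "open" are said of these compounds alone.

Compound 3 `c1ccc2c(-c3cn4ccnc4c(-c4ccc5ncn(C6CCCCC6)c5c4)n3)cccc2c1` gives 41.3% in a functional assay on T47D cells (Homo sapiens) for inhibition, read by sulforhodamine B assay, with a stated time of 48 h, tested at 10 uM (a lower number here means less inhibition, a higher number more inhibition at the concentration tested (going by the name of the read-out)), the lowest of the three numbers measured, while compound 1 `Brc1cn2ccnc2c(-c2ccc3ncn(C4CCCCC4)c3c2)n1` gives 49.7% and compound 2 `O=Cc1ccc(-c2cn3ccnc3c(-c3ccc4ncn(C5CCCCC5)c4c3)n2)cc1` gives 98%. Compound 4 `Fc1ccc(-c2cn3ccnc3c(-c3ccc4ncn(C5CCCCC5)c4c3)n2)cc1` differs from compound 3 by 4-fluorophenyl in place of naphthalen-1-yl on an aromatic carbon. Within the data shown here, two steps bear on this: a number 56.7 percentage points lower from compound 2 to compound 3 (beyond the scatter), and a number 8.4 percentage points lower from compound 1 to compound 3 (within the scatter). Since a single six-membered carbon ring with a formyl group sat far above the naphthalen-1-yl compound, and a 4-fluorophenyl is again a single carbon ring, an upward step is expected for compound 4 in this assay, the expected step being a number 23.7 percentage points higher from compound 3 to compound 4 (beyond the scatter), though its size is uncertain. Compound 4 is therefore estimated at 65%, with a range from 35% to 95%.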

Compound 4, a percentage reported as inhibition, at one concentration (the size of the read-out at that concentration, not a potency): 33.3%
Beside the measured number, compound 4's estimate is 31.7 percentage points above it, and the stated range ends above it.
By their numbers in this assay, from the lowest: compounds 4, 3 and 1 (each within the scatter of the next, the first and the last beyond it); then compound 2.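

Going from naphthalen-1-yl to 4-fluorophenyl at this position gives a number 8 percentage points lower from compound 3 to compound 4 (within the scatter) in this assay and so does not separate the two groups. Fluoro in place of formyl on the same ring gives a number 64.7 percentage points lower from compound 2 to compound 4 (beyond the scatter) and ties the high number of compound 2 to its formyl group rather than to a single carbon ring as such. Replacing bromo with 4-fluorophenyl gives a number 16.4 percentage points lower from compound 1 to compound 4 (beyond the scatter) and so a carbon ring here does not by itself raise the number over bromo, with compound 2 alone going against this.

On these data alone, whether a carboxylic acid, a hydroxymethyl group or an amine at the 4-position of the phenyl ring would match the formyl group remains open. Nothing available gives a reason for these steps.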